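Trading fluoro for trifluoromethyl on the shared core

This account rests on a few compounds, and the source may have more. Where it says the series, first, only, none or still open, it means among the compounds named here.

In a functional assay on HepG2 cells (Homo sapiens) for cytotoxicity, read by MTT assay, with a stated time of 24 h (on this read-out lower numbers stand for stronger inhibition and higher numbers for weaker inhibition), compound 1 `O=C1/C(=C/c2cccnc2)CN(S(=O)(=O)c2ccc([N+](=O)[O-])cc2)C/C1=C\c1ccccc1F` gives 12800 nM. Compound 3 `O=C1/C(=C/c2cccnc2)CN(S(=O)(=O)c2ccc(Br)cc2)C/C1=C\c1ccccc1F` gives 8700 nM, which cannot be told apart from compound 1, as a 1.5-fold lower number from compound 1 to compound 3 (0.17 log units; within the scatter) shows. Compound 2 `O=C1/C(=C/c2cccnc2)CN(S(=O)(=O)c2ccc(C(F)(F)F)cc2)C/C1=C\c1ccccc1F` gives 2400 nM, so compound 1 belongs to the upper pair of the three numbers.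

Compound 4 `O=C1/C(=C/c2cccnc2)CN(S(=O)(=O)c2ccc([N+](=O)[O-])cc2)C/C1=C\c1ccccc1C(F)(F)F` keeps the rest of compound 1 and changes a single group: trifluoromethyl in place of fluoro on an aromatic carbon. This is trifluoromethyl in place of fluoro on an aromatic carbon, ortho to a large group.

Among the measured compounds shown here, no measured pair shows this swap, because all three measured steps change a different group of the molecule. The closest guide is a 5.3-fold lower number from compound 1 to compound 2 (0.73 log units; beyond the scatter), where trifluoromethyl also enters, though it replaces nitro and stands elsewhere. The step of a 3.6-fold higher number from compound 2 to compound 3 (0.56 log units; beyond the scatter) shows that leaving trifluoromethyl out of that same place can also matter. These steps are modest, and they come from another site, so only part of their size is carried over. A small move toward a lower number in this assay is expected, without a clear step beyond the scatter.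

The expected change is a 1.7-fold lower number from compound 1 to compound 4 (0.23 log units; within the scatter).

For compound 4 the estimated value is 7500 nM, with an expected range from 2800 nM to 20000 nM.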

Compound 4, half-maximal inhibitory concentration: 9370 nM
Compound 4: middle estimate off by 1.2-fold (0.10 log units), on the low side, within the range that was stated.
By their numbers in this assay, from the lowest: compound 2; then compounds 3, 4 and 1 (each within the scatter of the next).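

In this assay, the first change made at this position gives a 1.4-fold lower number from compound 1 to compound 4 (0.14 log units; within the scatter), so replacing fluoro with trifluoromethyl, a group with more heavy atoms, leaves the number indistinguishable from that of compound 1. The same group gave a step beyond the scatter at the other site, a 5.3-fold lower number from compound 1 to compound 2 (0.73 log units; beyond the scatter), where it replaced nitro, so its entry does not shift the number in the same way at both sites, at least in these two examples. No measurement here explains this difference or the flat result at this position.

On these data alone, a single swap at a single position still says little about how much this place can accept, and whether an amine, a carboxylic acid or a longer chain in place of fluoro would move the number beyond the scatter remains open. It is also unknown whether the fluoro to trifluoromethyl swap would stay as quiet on the background of compound 2 or compound 3, where the nitro group has been replaced by trifluoromethyl or bromo.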